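Series notes: the step to a 3-chloro-4-hydroxyphenyl analogue

A few compounds are considered here, and "the series" means these few. Any claim that something is new, unique, unknown or untested is made for them only; others in the source may bear on it.

In a functional assay on MCF7 cells (Homo sapiens) for cytotoxicity, read by MTT assay, with a stated time of 72 h (on this read-out lower numbers stand for stronger inhibition and higher numbers for weaker inhibition), compound 1 `COc1ccc(/C=C2\CCC/C(=C\c3cccc(Br)c3)C2=O)cc1OC` gives 5300 nM, compound 2 `COc1ccc(/C=C2\CCC/C(=C\c3ccc(OC)c(OC)c3)C2=O)cc1` gives 7800 nM and compound 3 `COc1ccc(/C=C2\CCC/C(=C\c3cccc(O)c3)C2=O)cc1OC` gives 2900 nM. The number for compound 3 is not separated from the bromo analogue: a 1.8-fold lower number from compound 1 to compound 3 (0.26 log units; within the scatter). It is separated only on the other side, and modestly: a 2.7-fold lower number from compound 2 to compound 3 (0.43 log units; beyond the scatter). Compound 4 `COc1ccc(/C=C2\CCC/C(=C\c3ccc(O)c(Cl)c3)C2=O)cc1OC` carries 3-chloro-4-hydroxyphenyl in place of 3-hydroxyphenyl on a double-bonded chain carbon bound to a double-bonded ring carbon. The measured exchanges at this place are all small, the remaining one being a 1.5-fold higher number from compound 1 to compound 2 (0.17 log units; within the scatter). For the measured compounds named here, no measured compound has chloro on this ring, so the series gives no direct precedent, and no direction can be argued from it. In this assay no shift beyond the scatter is therefore expected, the estimated change being a 1.1-fold higher number from compound 3 to compound 4 (0.04 log units; within the scatter). For compound 4 the estimate is 3200 nM, with an expected range of 1300 nM to 7500 nM.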

Compound 4, half-maximal inhibitory concentration: 12300 nM
Compound 4: middle estimate off by 3.8-fold (0.58 log units), on the low side; measured number outside the range, above it.
By their numbers in this assay, from the lowest: compounds 3, 1, 2 and 4 (each within the scatter of the next, the first and the last beyond it).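

In this assay, for the compounds shown here, the widest step at this place so far is a 4.2-fold higher number from compound 3 to compound 4 (0.63 log units; beyond the scatter), so the group here can move the number further than the earlier exchanges did. The 3-chloro-4-hydroxyphenyl group also separates from the bromo analogue, with a 2.3-fold higher number from compound 1 to compound 4 (0.37 log units; beyond the scatter), but not on the other side, with a 1.6-fold higher number from compound 2 to compound 4 (0.20 log units; within the scatter). No measurement offered here accounts for the rise in the number.

The exchange from 3-hydroxyphenyl to 3-chloro-4-hydroxyphenyl adds chlorine and also changes where the hydroxy stands, and the compounds shown do not separate these two changes. Going by these compounds, how an amine or a carboxylic acid on this ring would compare also remains open.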